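The source may hold more compounds than are shown below. What is called first, only, known or untested is meant among the compounds shown, and "the series" means these compounds.

In a functional assay on K562 cells (Homo sapiens) for antiproliferative activity, with a stated time of 72 h (on this read-out higher numbers stand for weaker inhibition and lower numbers for stronger inhibition), compound 1 `COc1cc(CNc2ncnc3c2ncn3[C@@H]2O[C@H](CO)[C@@H](O)[C@H]2O)cc(OC)c1` gives > 166000 nM, which is a limit and not a number. Compound 1 thus stands at the limit of > 166000 nM in this assay, at which 1 of the 3 values shown sits. Two compounds with other aryl groups on the same core give numbers: compound 2 `OC[C@H]1O[C@@H](n2cnc3c(NCc4ccc(F)c(Cl)c4)ncnc32)[C@H](O)[C@@H]1O` reads 5500 nM, and compound 3 `OC[C@H]1O[C@@H](n2cnc3c(NCc4cccc(O)c4O)ncnc32)[C@H](O)[C@@H]1O` reads 25800 nM. The steps to them are an at least 30-fold lower number from compound 1 to compound 2 (1.47 log units; beyond the scatter) and an at least 6.4-fold lower number from compound 1 to compound 3 (0.80 log units; beyond the scatter), and between them lies a 4.7-fold higher number from compound 2 to compound 3 (0.67 log units; beyond the scatter).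

Compound 4 `COc1cc(CNc2ncnc3c2ncn3[C@@H]2O[C@H](CO)[C@@H](O)[C@H]2O)cc(OC)c1O` keeps both methoxy groups of compound 1 and adds one group: hydroxy in place of hydrogen on an aromatic carbon. This is hydroxy in place of hydrogen on an aromatic carbon, ortho to two methoxy groups and para to a large group. Among the compounds with values here, no measured step isolates this addition. Within the data shown here, the closest guide is compound 3, the only measured compound with ring hydroxy groups, reached by an at least 6.4-fold lower number from compound 1 to compound 3 (0.80 log units; beyond the scatter), though that step also removes both methoxy groups.

A modest step toward lower numbers in this assay is therefore expected, estimated as an at least 2.7-fold lower number from compound 1 to compound 4 (0.44 log units; beyond the scatter). For compound 4 the expected value is 60000 nM, with an estimated range of 20000 nM to 150000 nM.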

Compound 4, half-maximal inhibitory concentration: > 166000 nM
Compound 4 gave a limit, no number; the forecaster's own chance of this, stated with the estimate: 35%; middle value at least 2.7-fold (0.44 log units) from the limit.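

Compound 1 and compound 4 both sit at a limit in this assay, so no step between them can be read: the limit of > 166000 nM in this assay, at which 2 of the 4 values shown sit.

On these data alone, whether hydroxy in place of hydrogen on an aromatic carbon of compound 1 changes the half-maximal inhibitory concentration at all remains open.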